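The source may hold more compounds than are shown below. What is called first, only, known or untested is meant among the compounds shown, and "the series" means these compounds.

Measured so far:
- compound 1 `CCc1ccc(-c2nn3cc(-c4cccc(N)c4)nc3s2)cc1` gives 8100 nM
- compound 2 `C=C(Br)C(=O)Nc1cccc(-c2cn3nc(Cc4cccc(OC)c4)sc3n2)c1` gives 2500 nM
- compound 3 `COc1cccc(Cc2nn3cc(-c4cccc(N)c4)nc3s2)c1` gives 24000 nM

These three numbers come from a functional assay on HeLa cells (Homo sapiens) for inhibition, read by cell counting, with a stated time of 4 days; a lower number here means a stronger inhibitor, a higher number a weaker inhibitor. Compound 2 has the lowest number of the three: compound 1 stands nearer to it, while compound 3 stands furthest away, with a 9.6-fold higher number from compound 2 to compound 3 (0.98 log units; beyond the scatter) separating the two.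

Compound 4 `C=C(Br)C(=O)Nc1cccc(-c2cn3nc(-c4ccc(Cl)cc4)sc3n2)c1` has not yet been measured. It differs from compound 2 in one place: 4-chlorophenyl in place of 3-methoxybenzyl on an aromatic carbon.

For the measured compounds named here, the only measured step, the one from compound 2 to compound 3, concerns the other end of the molecule and so does not speak directly to this change. What does bear on it is the pair of compound 1 and compound 3, which share the free amine and differ at the same aromatic carbon: compound 1, carrying an aryl group there, gives 8100 nM, while compound 3, carrying the 3-methoxybenzyl group, gives 24000 nM. On that slender basis, a modest move toward a lower number is expected for compound 4, amounting to a 2.1-fold lower number from compound 2 to compound 4 (0.32 log units; beyond the scatter).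

Compound 4 is therefore estimated at 1200 nM, with a likely range from 400 nM to 4000 nM.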

Compound 4, half-maximal inhibitory concentration: 3000 nM
Compound 4: the middle estimate sits 2.5-fold (0.40 log units) below what was measured; low and high end bracket the measured number.
By their numbers in this assay, from the lowest: compounds 2 and 4 (each within the scatter of the next); then compound 1; then compound 3.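

In this assay, putting 4-chlorophenyl in place of 3-methoxybenzyl on this aromatic carbon gives a 1.2-fold higher number from compound 2 to compound 4 (0.08 log units; within the scatter), so with the (1-bromoethenyl)carbonyl group on the nitrogen the two groups cannot be told apart. For the compounds shown here, the exchange is not a small one on paper, as the group that leaves has 9 heavy atoms and a hydrogen-bond acceptor, while the group that enters has 7 heavy atoms, a chlorine and no acceptor, and the printed gap between the free amines compound 1 at 8100 nM and compound 3 at 24000 nM has no counterpart in this pair. Nothing measured here explains why this exchange leaves the number within the scatter.

As far as these compounds go, both groups tested in this pair are built on a six-membered aromatic ring of carbon, so it remains open how this position would respond to something quite different, such as an amine, a carboxylic acid or a longer chain. Also open, from the compounds shown here alone, is how 4-chlorophenyl would behave on the free amine, which would show whether the two ends of the molecule act independently of each other.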